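The source may report more compounds than this note shows. Statements on the series, on what has been measured and on what is new or still open speak of the compounds shown alone.

In a functional assay on CHO cells for antagonist activity at prostaglandin E2 receptor EP3 subtype (Homo sapiens), read by cAMP accumulation (a lower number here means a stronger inhibitor, a higher number a weaker inhibitor), compound 1 `CCn1ncc2c(F)cc(-c3ccc(C(CC)(CC)c4nnc(C)[nH]4)c(=O)[nH]3)cc21` gives 90 nM, compound 2 `CCn1ncc2c(F)cc(-c3ccc(C(CC)(CC)c4ncn(C)n4)c(=O)[nH]3)cc21` gives 96 nM and compound 3 `CC(C)C(c1ncco1)c1ccc(-c2ccc3cccc(F)c3c2)[nH]c1=O` gives 64 nM. Compound 2 holds the highest of the three numbers; compound 1 sits nearest and compound 3 furthest, and both gaps are within the scatter. Compound 4 `CCn1ncc2c(F)cc(-c3ccc(C(CC)(CC)c4nncn4C)c(=O)[nH]3)cc21` differs from compound 2 by 4-methyl-4H-1,2,4-triazol-3-yl in place of 1-methyl-1H-1,2,4-triazol-3-yl on a saturated chain carbon bound to an aromatic carbon and two saturated chain carbons. Within the data shown here, the one measured step that bears on this place is a 1.1-fold higher number from compound 1 to compound 2 (0.03 log units; within the scatter), which changed the group at the same place and stayed within the scatter. A further change of the same kind is therefore expected to move the number by no more than the scatter, in either direction. Compound 4 is accordingly expected to give 100 nM in this assay, within a range of 50 nM to 200 nM. That estimate means an expected step of a 1.0-fold higher number from compound 2 to compound 4 (0.02 log units; within the scatter).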

Compound 4, half-maximal inhibitory concentration: 120 nM
Compound 4: middle estimate off by 1.2-fold (0.08 log units), on the low side, and the stated range covers the measured number.
By their numbers in this assay, from the lowest: compounds 3, 1, 2 and 4 (each within the scatter of the next).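

Placing the methyl at a different point on the triazole, on a saturated chain carbon bound to an aromatic carbon and two saturated chain carbons, gives no step beyond the scatter in this assay (a 1.3-fold higher number from compound 2 to compound 4 (0.10 log units; within the scatter)) and (a 1.3-fold higher number from compound 1 to compound 4 (0.12 log units; within the scatter)). Compounds 1, 2 and 4 therefore read alike across all three methyl-triazole isomers, so this place tolerates the rearrangement. No data here offer an explanation for this flat result. On these data alone, whether the triazole itself is needed remains open. An unmethylated 1,2,4-triazole, a carboxylic acid or an amine at this place would test that.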